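The compounds below may be only part of what the source reports. "The series", "measured", "known", "first", "only" and "open" are said of these compounds alone.

Measured compounds:

compound 1, `Cn1cncc1C(OCc1nc(N2CCC(C(N)=O)CC2)c(C#N)cc1-c1cccc(Cl)c1)c1ccc(C#N)cc1` — in this assay 1.5 nM
compound 2, `Cn1cncc1C(OCc1ccc(C#N)nc1-c1cccc(Cl)c1)c1ccc(C#N)cc1` — 1.8 nM
compound 3, `Cn1cncc1C(OCc1ccc(C#N)cc1-c1cc(F)cc(F)c1)c1ccc(C#N)nc1` — 25 nM

Three compounds have been run in a functional assay on NIH3T3 cells (Mus musculus); on this read-out higher numbers stand for an effect only at larger amounts of compound and lower numbers for an effect already at smaller amounts. Compound 1 gives 1.5 nM, compound 2 gives 1.8 nM, and compound 3 gives 25 nM. Compound 2 thus stands second highest of the three numbers; the gap to compound 1 lies within the scatter, so no order between these two can be read, while compound 3 sits well beyond the scatter above compound 2.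

Compound 4, `Cn1cncc1C(OCc1ccc(C#N)nc1-c1ccccc1)c1ccc(C#N)cc1`, is not yet measured. It differs from compound 2 in one place: hydrogen in place of chloro on an aromatic carbon. Among the measured compounds shown here, no pair of measured compounds differing in a single place is available, so nothing in the numbers shows how such a change behaves here. Loss of a chloro group with no replacement is expected to cost a little rather than help, so for compound 4 a modest step toward a higher number is expected, a 2.8-fold higher number from compound 2 to compound 4 (0.44 log units; beyond the scatter), close to the edge of the scatter. The estimate for compound 4 is 5 nM, with a range from 1.5 nM to 20 nM.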

Compound 4, half-maximal effective concentration: 19 nM
Beside the measured number, compound 4's estimate is 3.8-fold (0.58 log units) below it; low and high end bracket the measured number.
By their numbers in this assay, from the lowest: compounds 1 and 2 (each within the scatter of the next); then compounds 4 and 3 (each within the scatter of the next).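

Among the compounds shown here, the change from 3-chlorophenyl to phenyl gives the first reading of this position: in this assay, hydrogen in place of chloro on the aromatic carbon comes out as an 11-fold higher number from compound 2 to compound 4 (1.02 log units; beyond the scatter), a large step well beyond the scatter. Within this pair, then, one chlorine, a single heavy atom with no hydrogen-bond donor or acceptor and no net charge, counts for much of the low number that compound 2 shows. Nothing at hand explains why the loss of this one atom weighs so heavily.

The compounds shown leave open whether the low number needs chloro itself or would also hold with fluoro, methyl or an amine on that aromatic carbon. They also leave open whether the same change would weigh as much in compound 1, which carries the same 3-chlorophenyl group on a more substituted core.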